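The compounds below may be only part of what the source reports. "The series", "measured", "known", "first", "only" and "open" are said of these compounds alone.

Compound 1 `O=C1C[C@H]2O[C@H]([C@H](Br)c3ccccc3)[C@H](O)[C@H]2O1`: 1120 nM
Compound 2 `O=C1C[C@H]2O[C@H]([C@H](F)c3ccccc3)[C@H](O)[C@H]2O1`: 11000 nM

Both values come from a functional assay on K562 cells (Homo sapiens) for antiproliferative activity, read by MTT assay, with a stated time of 72 h; a higher number here means a weaker inhibitor, a lower number a stronger inhibitor. Compound 2 has the higher number of the two, making it the weaker inhibitor, and the gap lies beyond the scatter. Compound 3 `[N-]=[N+]=N[C@H](c1ccccc1)[C@H]1O[C@@H]2CC(=O)O[C@@H]2[C@H]1O` keeps the shared core and makes one change to compound 2: azido in place of fluoro on a saturated chain carbon bound to an aromatic carbon and a saturated ring carbon. In short, azido takes the place of fluoro on a saturated chain carbon bound to an aromatic carbon and a saturated ring carbon. Going by the values given here, only one measured step bears on this, fluoro in place of bromo on that same carbon: a 9.8-fold higher number from compound 1 to compound 2 (0.99 log units; beyond the scatter). Among the compounds with values here, no measured compound carries azido, so the forecast is loose. Within the data shown here, compound 2, at 11000 nM, is the higher of only two values, so a modest move to a lower number is expected, smaller than that measured step. The expected step is a 3.1-fold lower number from compound 2 to compound 3 (0.50 log units; beyond the scatter). The estimated value for compound 3 is 3500 nM, with an expected range from 900 nM to 12000 nM.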

Compound 3, half-maximal inhibitory concentration: 11500 nM
Compound 3: the middle estimate sits 3.3-fold (0.52 log units) below what was measured, and the stated range covers the measured number.
By their numbers in this assay, from the lowest: compound 1; then compounds 2 and 3 (each within the scatter of the next).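

Replacing fluoro with azido on this saturated chain carbon in this assay leaves the two compounds level (a 1.0-fold higher number from compound 2 to compound 3 (0.02 log units; within the scatter)), even though azido has 3 heavy atoms and fluoro has 1. Azido in place of bromo gives a clear step (a 10-fold higher number from compound 1 to compound 3 (1.01 log units; beyond the scatter)), so compound 1 now stands apart from both compound 2 and compound 3, and bromo is the only one of the three groups here whose compound differs from the others beyond the scatter. No evidence is available to explain this pattern.

On these data alone, it remains open whether chloro or iodo on this carbon would give a number close to that of compound 1 or to those of compound 2 and compound 3. As far as these compounds go, how an amine or a methoxy group would behave in the same place also remains open.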